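The source may report more compounds than this note shows. Statements on the series, on what has been measured and on what is new or still open speak of the compounds shown alone.

Values in an ADME assay on the whole organism (Rattus norvegicus, strain Sprague-Dawley) for pharmacokinetics, read by LC-MS, at a dose of 5 mg/kg by the oral route; on this read-out higher numbers stand for higher exposure at the dose given and lower numbers for lower exposure:
Compound 1 `Cc1cccc(Cl)c1CN1CCc2cc(-c3c(C)nc(C)c([C@H](OC(C)(C)C)C(=O)O)c3N3CCC(C)(C)CC3)ccc2C1`: 9210 ng.h/mL
Compound 2 `Cc1nc(C)c([C@H](OC(C)(C)C)C(=O)O)c(N2CCC(C)(C)CC2)c1-c1ccc2c(c1)CCN(Cc1cccc(F)c1F)C2`: 5090 ng.h/mL

Compound 2 stands within the usual scatter of compound 1, so these two numbers cannot be ranked. Compound 3 `Cc1nc(C)c([C@H](OC(C)(C)C)C(=O)O)c(N2CCC(C)(C)CC2)c1-c1ccc2c(c1)CCN(Cc1ccc(F)cc1F)C2` differs from compound 2 by one change: 2,4-difluorophenyl in place of 2,3-difluorophenyl on a saturated chain carbon bound to an amine nitrogen in a ring. The two have the same atoms, joined differently. Among the measured compounds shown here, only one measured step bears on this place, a 1.8-fold lower number from compound 1 to compound 2 (0.26 log units; within the scatter), and it exchanged 2-chloro-6-methylphenyl for 2,3-difluorophenyl. With that step inside the scatter, no step beyond the scatter is expected in this assay. The expected change is a 1.1-fold higher number from compound 2 to compound 3 (0.03 log units; within the scatter). For compound 3 the estimated value is 5500 ng.h/mL, with an expected range of 2700 ng.h/mL to 11000 ng.h/mL.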

Compound 3, area under the concentration-time curve: 4420 ng.h/mL
Compound 3: middle estimate off by 1.2-fold (0.09 log units), on the high side, and the stated range covers the measured number.
By their numbers in this assay, from the lowest: compounds 3, 2 and 1 (each within the scatter of the next, the first and the last beyond it).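

Moving one fluorine, from 2,3-difluorophenyl to 2,4-difluorophenyl, gives a 1.2-fold lower number from compound 2 to compound 3 (0.06 log units; within the scatter) in this assay, so these two arrangements cannot be told apart on this read-out. Among the compounds shown here, exchanging 2-chloro-6-methylphenyl for 2,4-difluorophenyl gives a 2.1-fold lower number from compound 1 to compound 3 (0.32 log units; beyond the scatter) and is the first step at this place to pass the scatter, though only modestly. Nothing available gives a reason for either step.

As far as these compounds go, how a pyridine ring or a methoxy-bearing phenyl would read at this place remains open.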